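The source may hold more compounds than are shown below. What is called first, only, known or untested is meant among the compounds shown, and "the series" means these compounds.

Working notes on the series, read in a physicochemical assay for solubility, in phosphate buffer, measured as kinetic solubility, at pH 7.4; on this read-out lower numbers stand for lower solubility and higher numbers for higher solubility. Compound 1 (`Cc1oc(-c2ccccc2Cl)nc1CN1CCC(C(=O)NCCCN2C[C@H](C)C[C@H](C)C2)CC1`) gives > 72 ug/mL, which is a limit of the assay and not a number. Among the compounds with values here, compound 2 (`Cc1oc(-c2c(Cl)cccc2C(F)(F)F)nc1CN1CCC(C(=O)NCCCN2C[C@H](C)C[C@H](C)C2)CC1`) gives 65.1 ug/mL, the only true number so far. Compound 3 (`Cc1cccc(-c2nc(CN3CCC(C(=O)NCCCN4C[C@H](C)C[C@H](C)C4)CC3)c(C)o2)c1`) has 3-methylphenyl in place of 2-chloro-6-(trifluoromethyl)phenyl on an aromatic carbon of a five-membered aromatic ring with 1 nitrogen and 1 oxygen: 3-methylphenyl in place of 2-chloro-6-(trifluoromethyl)phenyl on an aromatic carbon. Within the data shown here, one measured step bears on this change, trifluoromethyl in place of hydrogen on an aromatic carbon, and it shows an at least 1.1-fold lower number from compound 1 to compound 2 (0.04 log units; that floor lies within the scatter). That step is only a floor because of the limit of > 72 ug/mL in this assay, at which 1 of the 2 values shown sits. On this evidence, no change beyond the scatter is expected in this assay, with a small rise the likelier direction. The expected move is a 1.0-fold higher number from compound 2 to compound 3 (0.02 log units; within the scatter). For compound 3 the estimate is 68 ug/mL, with an expected range of 45 ug/mL to 80 ug/mL.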

Compound 3, solubility: > 69 ug/mL
Compound 3 was reported as a limit; the forecaster's own chance of this, stated with the estimate: 55%; at least 1.0-fold (0.00 log units) between middle value and limit.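

In this assay compound 3 gives > 69 ug/mL, which is a limit of the assay and not a number. On the aromatic carbon of the five-membered ring, 3-methylphenyl in place of 2-chloro-6-(trifluoromethyl)phenyl gives an at least 1.0-fold higher number from compound 2 to compound 3 (0.02 log units; that floor lies within the scatter), and only this floor can be read for the change: the limit of > 69 ug/mL in this assay, at which 1 of the 3 values shown sits. The 3-methylphenyl and 2-chlorophenyl compounds both end at a limit, so the step between compound 1 and compound 3 cannot be read: the limit of > 72 ug/mL in this assay, at which 1 of the 3 values shown sits.

From the compounds shown here alone, the true values of compound 1 and compound 3 stay open, and with them any ranking of the aryl groups at this position. Also open, going by these compounds, is how an amine or a carboxylic acid on this phenyl ring would read in this assay.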